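A few compounds are considered here, and "the series" means these few. Any claim that something is new, unique, unknown or untested is made for them only; others in the source may bear on it.

Working notes on the diaryl urea series. Compound 1 `Cc1ccccc1-n1cc(COc2cccc(NC(=O)Nc3ccc(Cl)c(C(F)(F)F)c3)c2)nn1` gives 3440 nM in a functional assay on HepG2 cells (Homo sapiens) for inhibition, read by MTT assay, with a stated time of 72 h; on this read-out lower numbers stand for stronger inhibition and higher numbers for weaker inhibition. Compound 2 `O=C(Nc1cccc(OCc2cn(-c3cccc(F)c3)nn2)c1)Nc1ccc(Cl)c(C(F)(F)F)c1` gives 2120 nM, and compound 3 `O=C(Nc1cccc(OCc2cn(-c3ccccc3Cl)nn2)c1)Nc1ccc(Cl)c(C(F)(F)F)c1` gives 1960 nM. Compound 3 stands at the lowest of the three numbers, but the steps of a 1.8-fold lower number from compound 1 to compound 3 (0.24 log units; within the scatter) and a 1.1-fold lower number from compound 2 to compound 3 (0.03 log units; within the scatter) are both within the scatter, as is a 1.6-fold lower number from compound 1 to compound 2 (0.21 log units; within the scatter); none of the three substituent swaps on the aryl group of the triazole has moved the read-out beyond repeat variation.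

Compound 4 `O=C(Nc1cccc(OCc2cn(-c3ccccc3I)nn2)c1)Nc1ccc(Cl)c(C(F)(F)F)c1` differs from compound 3 by iodo in place of chloro on an aromatic carbon. For the measured compounds named here, no measured step exchanges one halogen for another at the same position, so the only bearing comes from the three steps above, all of which vary the same aryl group and all of which stay within the scatter. The change from chloro to iodo keeps the count of heavy atoms, donors and acceptors on that ring the same, so no step beyond the scatter is expected in this assay for compound 4; the estimated step is a 1.1-fold lower number from compound 3 to compound 4 (0.04 log units; within the scatter). Compound 4 is therefore expected to give about 1800 nM, with a range from 900 nM to 3600 nM.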

Compound 4, half-maximal inhibitory concentration: 2870 nM
Beside the measured number, compound 4's estimate is 1.6-fold (0.20 log units) below it; low and high end bracket the measured number.
By their numbers in this assay, from the lowest: compounds 3, 2, 4 and 1 (each within the scatter of the next).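

The series now holds a direct exchange of one halogen for another at a single place, 2-chlorophenyl to 2-iodophenyl, and in this assay it gives a 1.5-fold higher number from compound 3 to compound 4 (0.17 log units; within the scatter), so this read-out does not separate chloro from iodo on a carbon ortho to a large group. The other two exchanges tell the same story, with a 1.4-fold higher number from compound 2 to compound 4 (0.13 log units; within the scatter) against the 3-fluorophenyl group and a 1.2-fold lower number from compound 1 to compound 4 (0.08 log units; within the scatter) against the methyl of the 2-methylphenyl group, so the flat picture from the first three aryl groups now extends to a fourth. Nothing at hand speaks to why the numbers lie so close together.

Going by these compounds, it remains open whether any group on this aryl ring can move the number beyond the scatter, since the four compounds carry only halogens or methyl, and an amine, a carboxylic acid or a longer chain at the same place would put that to the test. Also open, on these data alone, is whether the response stays as flat when the part shared by all four, the urea with its chloro and trifluoromethyl groups, is changed.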